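Swapping the aryl group on a tetrazole-bearing channel opener

This account rests on a few compounds, and the source may have more. Where it says the series, first, only, none or still open, it means among the compounds named here.

Three compounds share one core, a pyrazole amide carrying a tetrazole that in turn bears an aromatic ring. Compound 1 `Cc1cc(NC(=O)Cn2nnc(-c3ccccc3)n2)n(C2CCCCC2)n1` carries a plain phenyl and gives 96 nM in an assay on HEK293 cells for activation of Kir3.1/Kir3.2 (Homo sapiens), read by thallium flux; a higher number here means that more compound is needed for the effect, a lower number that less compound is needed. Compound 2 `Cc1cc(NC(=O)Cn2nnc(-c3cccnc3)n2)n(C2CCCCC2)n1` carries a pyridin-3-yl and gives 1930 nM in this assay. Compound 3 `Cc1cc(NC(=O)Cn2nnc(-c3ccc(F)c(F)c3)n2)n(C2CCCCC2)n1` carries a 3,4-difluorophenyl and gives 116 nM in this assay, which places compound 3 second highest of the three numbers, separated from compound 1 by a gap within the scatter and from compound 2 by a gap beyond it.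

The step to compound 4 `COc1ccc(-c2nnn(CC(=O)Nc3cc(C)nn3C3CCCCC3)n2)cc1` is 4-methoxyphenyl in place of 3,4-difluorophenyl on an aromatic carbon. For the measured compounds named here, two measured steps bear on it. Replacing phenyl gave a 1.2-fold higher number from compound 1 to compound 3 (0.08 log units; within the scatter), so two fluorines on the ring left the number essentially unchanged. Putting a ring nitrogen in place of a ring carbon gave a 20-fold higher number from compound 1 to compound 2 (1.30 log units; beyond the scatter), and going back gave a 17-fold lower number from compound 2 to compound 3 (1.22 log units; beyond the scatter). The methoxy group introduces an acceptor outside the ring while the ring itself stays carbon only, so the change resembles the first step more than the second. The expectation for compound 4 is a small shift, a 1.7-fold higher number from compound 3 to compound 4 (0.24 log units; within the scatter), likely within the scatter. Compound 4 is estimated at 200 nM, with a range from 60 nM to 800 nM.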

Compound 4, half-maximal effective concentration: 175 nM
For compound 4 the middle estimate is 1.1-fold (0.06 log units) above the measured one, and the stated range covers the measured number.
By their numbers in this assay, from the lowest: compounds 1, 3 and 4 (each within the scatter of the next); then compound 2.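

Methoxy in place of hydrogen on the phenyl ring gives (a 1.8-fold higher number from compound 1 to compound 4 (0.26 log units; within the scatter)), and 4-methoxyphenyl in place of 3,4-difluorophenyl gives (a 1.5-fold higher number from compound 3 to compound 4 (0.18 log units; within the scatter)). So in this assay this position takes a group counting one hydrogen-bond acceptor, where phenyl and 3,4-difluorophenyl count none, with no change beyond the scatter, and compounds 1, 3 and 4 cannot be ranked against one another. For the compounds shown here, the other comparison runs the opposite way, since 4-methoxyphenyl in place of pyridin-3-yl gives (an 11-fold lower number from compound 2 to compound 4 (1.04 log units; beyond the scatter)), which leaves compound 2, the only one with a ring nitrogen in this aromatic group, as the lone exception to an otherwise flat set, though nothing measured here accounts for that exception.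

From the compounds shown here alone, whether the high number belongs to ring nitrogen in general or to pyridin-3-yl in particular stays open, and pyridin-4-yl would be a direct test. Going by these compounds, it is also open how far this tolerance extends, for example to 3-methoxyphenyl, or to a ring bearing an amine or a carboxylic acid in place of the methoxy.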